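The source may report more compounds than this note shows. Statements on the series, on what has been measured and on what is new or still open speak of the compounds shown alone.

The shared core is that of compound 1 `Cc1c(C(=O)N/N=C\c2cccc(O)c2)oc2cccc(O)c12`, which in a functional assay on PC-3 cells (Homo sapiens) for inhibition (a higher number here means a weaker inhibitor, a lower number a stronger inhibitor), gives 17600 nM. Compound 2 `Cc1c(C(=O)N/N=C\c2cccc(F)c2)oc2cccc(O)c12` reaches only the limit of this assay, >= 40000 nM. Compound 3 `COc1cccc(/C=N\NC(=O)c2oc3cccc(O)c3c2C)c1` also stands at a limit, >= 40000 nM, and two of the three values shown sit there (the limit of >= 40000 nM in this assay, at which 2 of the 3 values shown sit). Measured from compound 1, the steps are an at least 2.2-fold higher number from compound 1 to compound 2 (0.35 log units; beyond the scatter) and an at least 2.2-fold higher number from compound 1 to compound 3 (0.35 log units; beyond the scatter), while a step that the two limits leave unreadable from compound 2 to compound 3. Compound 4 `Cc1c(C(=O)N/N=C\c2cc(Cl)ccc2O)oc2cccc(O)c12` differs from compound 2 by 5-chloro-2-hydroxyphenyl in place of 3-fluorophenyl on a carbon with a double bond to nitrogen. For the measured compounds named here, compound 1, the only one with a hydroxy on that ring, is the only one with a number, so a hydroxy entering again is expected to bring the number back down. The expected step is an at least 2.0-fold lower number from compound 2 to compound 4 (0.30 log units; that floor lies within the scatter). Compound 4 is estimated at 20000 nM, within 6000 nM to 40000 nM.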

Compound 4, half-maximal inhibitory concentration: 3120 nM
Beside the measured number, compound 4's estimate is 6.4-fold (0.81 log units) above it, outside the stated range (below it).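

For the compounds shown here, on the carbon with a double bond to nitrogen, the aryl group can move the number in this assay much further than the earlier compounds showed: 5-chloro-2-hydroxyphenyl gives an at least 12-fold lower number from compound 2 to compound 4 (1.10 log units; beyond the scatter) and an at least 12-fold lower number from compound 3 to compound 4 (1.10 log units; beyond the scatter). A hydroxy on that ring is not the whole story, as 5-chloro-2-hydroxyphenyl in place of 3-hydroxyphenyl still gives a 5.6-fold lower number from compound 1 to compound 4 (0.75 log units; beyond the scatter). The first two steps are floors, as compound 2 and compound 3 each stand at a limit: the limit of >= 40000 nM in this assay, at which 2 of the 4 values shown sit.

On these data alone, the chloro and the moved hydroxy arrive together in compound 4, so what each contributes stays open. As far as these compounds go, how an amine or a carboxylic acid on that ring would fare also remains unknown.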